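The compounds below may be only part of what the source reports. "The series", "measured", "known", "first", "only" and "open" are said of these compounds alone.

Compound 1 `CC(C)OCCOc1cccc2ccc(N)nc12` in an assay on cells with melanin-concentrating hormone receptor 1 (Homo sapiens) as the target, read by radioligand binding (a lower number here means a stronger inhibitor, a higher number a weaker inhibitor), gives > 2000 nM, which is a limit of the assay rather than a number.
Compound 2 `Nc1ccc2cccc(OCCC3CC3)c2n1` in this assay gives 492 nM.
Compound 3 `CC(C)=CCOc1cccc2ccc(N)nc12` in this assay gives > 2000 nM, again only a limit of the assay.
Compound 4 `Nc1ccc2cccc(OCC3CCC3)c2n1` has not yet been measured in this assay.

Compound 3 therefore stands only at a limit; of the three measured compounds only compound 2 has a true number, and the limit of > 2000 nM in this assay, at which 2 of the 3 values shown sit, is where the other two sit. The change to compound 4 is cyclobutyl in place of 2-methylprop-1-en-1-yl on a saturated chain carbon bound to an oxygen on an aromatic ring. Within the data shown here, two measured steps bear on it. The step of an at least 4.0-fold higher number from compound 2 to compound 3 (0.60 log units; beyond the scatter) is the reverse of closing an open, branched chain into a small ring, and it weakened binding. The step that the two limits leave unreadable from compound 1 to compound 3 cannot be read. On this basis the move to compound 4, which closes the chain into a ring again, is expected to run the other way, back toward the number seen for compound 2. The estimated step is an at least 2.8-fold lower number from compound 3 to compound 4 (0.45 log units; beyond the scatter). Compound 4 is expected to give 700 nM in this assay, between 200 nM and 2500 nM, with a real chance that only a limit is reported.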

Compound 4, half-maximal inhibitory concentration: 432 nM
Beside the measured number, compound 4's estimate is 1.6-fold (0.21 log units) above it; the range from low to high includes it.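

Placing cyclobutyl on this saturated chain carbon gives a true number where the two open groups give only limits of the assay, with an at least 4.6-fold lower number from compound 3 to compound 4 (0.66 log units; beyond the scatter) and an at least 4.6-fold lower number from compound 1 to compound 4 (0.66 log units; beyond the scatter). Both sizes are only minimum sizes, because each starts from a limit: the limit of > 2000 nM in this assay, at which 2 of the 4 values shown sit. Cyclobutyl and cyclopropylmethyl cannot be told apart in this place, with a 1.1-fold lower number from compound 2 to compound 4 (0.06 log units; within the scatter), so among these four compounds the two carrying a small carbon ring sit together and the two open chains sit at the limit.

The compounds shown leave open whether a larger ring, such as cyclopentyl, would keep this level of binding. A plain butyl chain, with neither a ring, a double bond nor an ether oxygen, would test whether the ring itself matters or whether the double bond and the ether oxygen are what the open chains have against them.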